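Removing one chloro from a dichlorinated purine-type core

The source may hold more compounds than are shown below. What is called first, only, known or untested is meant among the compounds shown, and "the series" means these compounds.

Compound 1 `ClCc1ccccc1Cn1cnc2c(Cl)ncnc21`: 33100 nM
Compound 2 `ClCc1ccc(Cn2cnc3nc(Cl)nc(Cl)c32)cc1`: 670 nM

In a functional assay on KM12 cells (Homo sapiens) for cytotoxicity, read by sulforhodamine B assay, with a stated time of 48 h (a higher number here means a weaker inhibitor of growth, a lower number a stronger inhibitor of growth), compound 2 gives 670 nM, the lowest of the two numbers seen so far; compound 1 shows a number that lies far higher than that of compound 2. Compound 3 `ClCc1ccc(Cn2cnc3ncnc(Cl)c32)cc1` has not yet been tested. It differs from compound 2 in one place: hydrogen in place of chloro on an aromatic carbon, between two ring nitrogen atoms. Among the compounds with values here, no measured pair shows this change on its own, so the step is expected to be a moderate loss, with the number for compound 3 rising by a 3.7-fold higher number from compound 2 to compound 3 (0.57 log units; beyond the scatter). Compound 3 is therefore estimated at 2500 nM, within a range from 700 nM to 9000 nM.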

Compound 3, concentration for total growth inhibition: 3380 nM
Compound 3: middle estimate off by 1.4-fold (0.13 log units), on the low side, within the range that was stated.
By their numbers in this assay, from the lowest: compound 2; then compound 3; then compound 1.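

Within the data shown here, replacing the chloro with hydrogen on this aromatic carbon, between two ring nitrogen atoms, gives a 5.0-fold higher number from compound 2 to compound 3 (0.70 log units; beyond the scatter) in this assay and so provides the first reading of this change on its own. In this one pair, the chloro at this position goes with stronger growth inhibition, a modest step that lies beyond the scatter.

The compounds shown leave open how an amine, a methoxy group or a bromo group on this carbon would compare with chloro and hydrogen, and no measurement here explains the step.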